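Selenol for amino on the fused core: growth inhibition outlook

The source may report more compounds than this note shows. Statements on the series, on what has been measured and on what is new or still open speak of the compounds shown alone.

Compound 2 `Nc1nc([SeH])nc2ncccc12` carries an amino group on its fused core. In a functional assay on MCF7 cells (Homo sapiens) for cytotoxicity, read by MTT assay, with a stated time of 72 h (on this read-out higher numbers stand for weaker inhibition of growth and lower numbers for stronger inhibition of growth), compound 2 gives > 100000 nM, which is a limit of the assay and not a number. Compound 1 `CSc1nc(NCCCCCO)c2ccccc2n1` is built on a different core. In this assay compound 1 gives > 100000 nM, also a limit. Compound 3 `[SeH]c1nc(NCc2ccccc2)c2cccnc2n1` shares the core of compound 2. In this assay compound 3 gives > 100000 nM, again a limit. Compound 2 therefore stands where every measured member stands, at the limit of > 100000 nM in this assay, at which 3 of the 3 values shown sit, and the numbers shown do not separate the three. Going by the values given here, no pair of them differs in a single place, so no measured step exists.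

Compound 4 `[SeH]c1nc([SeH])c2cccnc2n1` is the unmeasured analogue of compound 2. The change is one selenium atom in place of one nitrogen atom, on an aromatic carbon.

Among the compounds with values here, with three limits and no measured step to draw on, the expected step in this assay is a step that the limit leaves unreadable from compound 2 to compound 4, that is, none beyond the scatter. For compound 4 the estimate in this assay is 150000 nM, within 50000 nM to 500000 nM, with the assay most likely to return only a limit once more.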

Compound 4, concentration for total growth inhibition: 46100 nM
Estimate against measurement, compound 4: 3.3-fold (0.51 log units) above, and the stated range ends above it.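

Selenium in place of the amino nitrogen, on this aromatic carbon of the shared core, gives in this assay the first step of the series that can be read: an at least 2.1-fold lower number from compound 2 to compound 4 (0.33 log units; beyond the scatter). Going by these compounds alone, this position therefore responds to the change on this read-out, which the earlier compounds could not show, and the true size of the step stays unfixed on the compound 2 side. Compound 1, compound 2 and compound 3 remain at a limit of the assay and not a number: the limit of > 100000 nM in this assay, at which 3 of the 4 values shown sit.

On these data alone, whether the step belongs to selenium itself or simply to the loss of the amino group stays open. A thiol or a hydroxyl group on the same carbon would separate these two readings, and a result from either would show how far the step depends on selenium.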